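The source may report more compounds than this note shows. Statements on the series, on what has been measured and on what is new or still open speak of the compounds shown alone.

Measured in a functional assay on PC-3 cells (Homo sapiens) for antiproliferative activity, read by WST assay, with a stated time of 3 days; a lower number here means a stronger inhibitor, a higher number a weaker inhibitor:
- compound 1 `CCCCCOc1c(-c2cc(OC)c(OC)c(OC)c2)oc2ccccc2c1=O`: 22200 nM
- compound 2 `CCN(CC)CCCOc1c(-c2cc(OC)c(OC)c(OC)c2)oc2ccccc2c1=O`: 13600 nM

Only these two numbers exist, and compound 2 cannot be separated from compound 1: a 1.6-fold lower number from compound 1 to compound 2 (0.21 log units; within the scatter).

Next in the series is compound 3 `CCN(CC)CCCCCOc1c(-c2cc(OC)c(OC)c(OC)c2)oc2ccccc2c1=O`, not yet measured in this assay. The change is 2-(diethylamino)ethyl in place of diethylamino on a saturated chain carbon, three bonds along the chain from an oxygen on an aromatic ring. In words, 2-(diethylamino)ethyl stands in place of diethylamino on a saturated chain carbon, three bonds along the chain from an oxygen on an aromatic ring. Cut further out, the same difference reads 3-(diethylamino)propyl to 5-(diethylamino)pentyl.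

Going by the values given here, one measured step bears on this only loosely. It is the exchange of ethyl for diethylamino, a 1.6-fold lower number from compound 1 to compound 2 (0.21 log units; within the scatter), which stayed small. Among the compounds with values here, no measured pair keeps the diethylamino group and alters only the chain, so the data set no firm direction, and no step beyond the scatter is expected. The estimated step is a 1.2-fold lower number from compound 2 to compound 3 (0.09 log units; within the scatter). The expected value for compound 3 is 11000 nM, with an estimated range from 4500 nM to 24000 nM.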

Compound 3, half-maximal inhibitory concentration: 6600 nM
For compound 3 the middle estimate is 1.7-fold (0.22 log units) above the measured one; the measured number falls inside the stated range.
By their numbers in this assay, from the lowest: compound 3; then compounds 2 and 1 (each within the scatter of the next).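

Working notes: in this assay the change from 3-(diethylamino)propyl to 5-(diethylamino)pentyl gives the first step in the series that lies beyond the scatter (a 2.1-fold lower number from compound 2 to compound 3 (0.31 log units; beyond the scatter)), so with the diethylamino group kept, chain length at this position does register, though modestly. The new compound also makes the amine readable: on the chain of compound 1, diethylamino in place of hydrogen, five bonds along the chain from the oxygen on the aromatic ring, gives a modest step beyond the scatter (a 3.4-fold lower number from compound 1 to compound 3 (0.53 log units; beyond the scatter)), whereas the earlier comparison of compound 1 with compound 2 could not be separated from the scatter. Nothing available gives a reason for either step.

Going by these compounds alone, three compounds define only two chain lengths bearing the diethylamino group, so it remains open whether a longer chain, such as 7-(diethylamino)heptyl, would extend or reverse this step. Also open, from the compounds shown here alone, is whether the diethylamino group itself matters at the end of the chain, or whether another amine, such as piperidine, morpholine or dimethylamino, would serve equally well there.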